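The source may report more compounds than this note shows. Statements on the series, on what has been measured and on what is new or still open speak of the compounds shown alone.

Measured in a functional assay on MCF7 cells (Homo sapiens) for antiproliferative activity; a lower number here means a stronger inhibitor, a higher number a weaker inhibitor:
- compound 1 `O=C(Nc1ccc(O)c2c(=O)cc(-c3ccccc3Cl)oc12)c1ccc(Cl)c(Cl)c1`: 15000 nM
- compound 2 `Cc1ccc(C(=O)Nc2ccc(O)c3c(=O)cc(-c4ccccc4Cl)oc23)cc1`: 10000 nM
- compound 3 `COc1ccc(C(=O)Nc2ccc(O)c3c(=O)cc(-c4ccccc4Cl)oc23)cc1`: 3500 nM

Compound 3 has the lowest number of the three. Compound 4 `C[C@H](NC(=O)OC(C)(C)C)C(=O)Nc1ccc(O)c2c(=O)cc(-c3ccccc3Cl)oc12` keeps the shared core but carries 1-((tert-butoxycarbonyl)amino)ethyl in place of 4-methoxyphenyl on a carbonyl carbon. The closest evidence comes from the measured swaps at that carbonyl carbon: a 4.3-fold lower number from compound 1 to compound 3 (0.63 log units; beyond the scatter) and a 2.9-fold lower number from compound 2 to compound 3 (0.46 log units; beyond the scatter), both modest, and a 1.5-fold lower number from compound 1 to compound 2 (0.18 log units; within the scatter), within the scatter. All of them keep an aromatic ring there, so they guide this change only loosely. Leaving compound 3 has so far meant a higher number, so a modest rise is expected. The estimated change is a 2.3-fold higher number from compound 3 to compound 4 (0.36 log units; beyond the scatter). For compound 4 the expected value is 8000 nM, with an estimated range of 2500 nM to 30000 nM.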

Compound 4, half-maximal inhibitory concentration: 5500 nM
Beside the measured number, compound 4's estimate is 1.5-fold (0.16 log units) above it, within the range that was stated.
By their numbers in this assay, from the lowest: compounds 3, 4, 2 and 1 (each within the scatter of the next, the first and the last beyond it).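

In this assay, an aromatic ring on the carbonyl carbon proves unnecessary among these compounds: the ring-free 1-((tert-butoxycarbonyl)amino)ethyl group stays within the scatter of both 4-methoxyphenyl (a 1.6-fold higher number from compound 3 to compound 4 (0.20 log units; within the scatter)) and 4-methylphenyl (a 1.8-fold lower number from compound 2 to compound 4 (0.26 log units; within the scatter)). It also stands clear of 3,4-dichlorophenyl (a 2.7-fold lower number from compound 1 to compound 4 (0.44 log units; beyond the scatter)). No evidence is available that explains these numbers. Still open, going by these compounds, is how the free amine, or a plain alkyl chain, would behave on this carbonyl carbon. The part played by the tert-butoxycarbonyl group and the defined stereocentre also remains unresolved.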